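The source may hold more compounds than are shown below. What is called first, only, known or untested is meant among the compounds shown, and "the series" means these compounds.

Compound 1, `O=C(NO)c1cc(F)c(Cn2nnc(-c3ccccn3)n2)c(F)c1`, was examined in an ADME assay on 697 cells (Homo sapiens) for cytotoxicity, with a stated time of 48 h; a higher number here means a weaker inhibitor, a lower number a stronger inhibitor. In this assay compound 1 gives > 1000 nM, which is a limit of the assay rather than a measured number. Compound 2, `O=C(NO)c1cc(F)c(Cc2nnc(-c3ccncc3)s2)c(F)c1`, gives > 1000 nM in this assay, again only a limit. Compound 3, `Cn1c(Sc2c(F)cc(C(=O)NO)cc2F)nnc1-c1cccs1`, likewise gives > 1000 nM in this assay, also a limit. Compound 1 therefore stands at the limit of > 1000 nM in this assay, at which 3 of the 3 values shown sit, and no order among the three compounds can be read from these values, since none of them is a number.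

Compound 4, `Nc1ccc(-c2nnn(Cc3c(F)cc(C(=O)NO)cc3F)n2)cc1`, differs from compound 1 in one place: 4-aminophenyl in place of pyridin-2-yl on an aromatic carbon. Among the compounds with values here, no measured step between two compounds that differ in one place is available, so the expectation rests on the three limits alone. The expected step is a step that the limit leaves unreadable from compound 1 to compound 4, which is no change beyond the scatter. Compound 4 is estimated at 5000 nM, with a likely range from 1000 nM to 50000 nM, and most probably this assay will again report only a limit for it.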

Compound 4, half-maximal inhibitory concentration: > 1000 nM
Compound 4 ended at the assay's limit; the forecaster's own chance of this, stated with the estimate: 85%; the middle value lies beyond the limit too.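

Compound 1 and compound 4 both give only a limit in this assay, and no step can be read between them. The compounds shown leave open how any of them truly ranks, and whether swapping the group changes the result, as all share one limit: the limit of > 1000 nM in this assay, at which 4 of the 4 values shown sit.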